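Two isomeric dioxoimidazolidinyl rings on the same side chain

This account rests on a few compounds, and the source may have more. Where it says the series, first, only, none or still open, it means among the compounds named here.

Compound 1, `CCO/C(O)=C1\C(COCCn2ccnc2C)=NC(C)=C(C(=O)OC)C1c1ccccc1Cl`, gives 2.51 nM in a functional assay (aorta) with Rattus norvegicus as the target; a lower number here means a stronger inhibitor, a higher number a weaker inhibitor.
Compound 2, `CCO/C(O)=C1\C(COCCn2nncc2C(N)=O)=NC(C)=C(C(=O)OC)C1c1ccccc1Cl`, gives 100 nM in this assay.
Compound 3, `CCO/C(O)=C1\C(COCCN2CC(=O)NC2=O)=NC(C)=C(C(=O)OC)C1c1ccccc1Cl`, gives 20 nM in this assay.

Compound 3 sits in the middle of these three numbers: an 8.0-fold higher number from compound 1 to compound 3 (0.90 log units; beyond the scatter), while a 5.0-fold lower number from compound 2 to compound 3 (0.70 log units; beyond the scatter). Compound 4, `CCO/C(O)=C1\C(COCCN2C(=O)CNC2=O)=NC(C)=C(C(=O)OC)C1c1ccccc1Cl`, is the ring isomer of compound 3: 2,5-dioxoimidazolidin-1-yl in place of 2,4-dioxoimidazolidin-1-yl on a saturated chain carbon, two bonds along the chain from an oxygen on a saturated carbon. The two compounds contain the same atoms, only joined differently, and nothing else in the shared core changes.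

Going by the values given here, none of the measured steps tests this kind of swap. The steps of a 40-fold higher number from compound 1 to compound 2 (1.60 log units; beyond the scatter) and an 8.0-fold higher number from compound 1 to compound 3 (0.90 log units; beyond the scatter) replace one ring by a different one, and both move the number upward, but compound 3 already carries the dioxoimidazolidinyl ring, so those steps give only a loose guide. Among the compounds with values here, with no direct precedent, the expectation is a small change, not beyond the scatter: a 1.3-fold higher number from compound 3 to compound 4 (0.10 log units; within the scatter) is the estimated step. Compound 4 is therefore expected to give about 25 nM, within a range from 8 nM to 80 nM.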

Compound 4, half-maximal inhibitory concentration: 31.6 nM
Compound 4: the middle estimate sits 1.3-fold (0.10 log units) below what was measured, and the stated range covers the measured number.
By their numbers in this assay, from the lowest: compound 1; then compounds 3 and 4 (each within the scatter of the next); then compound 2.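

Exchanging 2,4-dioxoimidazolidin-1-yl for 2,5-dioxoimidazolidin-1-yl at this position gives a 1.6-fold higher number from compound 3 to compound 4 (0.20 log units; within the scatter), so in this assay the two ring isomers, which match in every count of atoms, donors and acceptors, cannot be told apart. The isomer keeps the standing of the first ring against the other side chains, with a 3.2-fold lower number from compound 2 to compound 4 (0.50 log units; beyond the scatter) and a 13-fold higher number from compound 1 to compound 4 (1.10 log units; beyond the scatter), which leaves the 2-methyl-1H-imidazol-1-yl group of compound 1 with the lowest number of the four compounds. Nothing available accounts for any of these differences.

As far as these compounds go, whether a simple amine or a carboxylic acid could take the place of the ring on this chain remains open. So does the outcome of a longer chain carrying the 2,5-dioxoimidazolidin-1-yl ring.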